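The source may report more compounds than this note shows. Statements on the series, on what has been measured and on what is new or still open speak of the compounds shown alone.

Working notes on the series. Compound 1 `COc1cccc(S(=O)(=O)c2n[nH]c3ccc(N4CCN(C)CC4)cc23)c1` is measured in a functional assay on HeLa cells for antagonist activity at 5-hydroxytryptamine receptor 6 (Homo sapiens) (on this read-out lower numbers stand for smaller maximal responses and higher numbers for larger maximal responses), where compound 1 gives 100%. Compound 2 `CN1CCN(c2cccc3c(S(=O)(=O)c4cccc5ccccc45)n[nH]c23)CC1` carries a different aryl group on the sulfonyl sulfur and in this assay compound 2 gives 100%. On these numbers compound 1 stands level with compound 2 within the scatter, so neither compound can be placed above the other; both sit at the full response of the reference.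

Compound 3 `CN1CCN(c2ccc3[nH]nc(S(=O)(=O)c4cccs4)c3c2)CC1` is not yet measured. It differs from compound 1 in one place: thiophen-2-yl in place of 3-methoxyphenyl on a sulfonyl sulfur. Within the data shown here, no step between two measured compounds shows what this exchange on the sulfonyl sulfur does to the maximal response, and both measured compounds reach the same full response. For the step in this assay no change beyond the scatter is expected, so the expected step is no change at the digits printed from compound 1 to compound 3 (within the scatter). Compound 3 is therefore estimated at 100%, with a range from 88% to 110%.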

Compound 3, largest response reached (reported as Imax), in percent of the reference or control that the assay uses: 96%
Beside the measured number, compound 3's estimate is 4 percentage points above it; measured number inside the range.
By their numbers in this assay, from the lowest: compounds 3, 1 and 2 (each within the scatter of the next).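

In this assay, among these compounds, thiophen-2-yl in place of 3-methoxyphenyl on a sulfonyl sulfur gives a number 4 percentage points lower from compound 1 to compound 3 (within the scatter), the first step that isolates this position. On the shared core, therefore, a five-membered aromatic ring with one hetero atom serves as well as the methoxy-bearing six-membered aromatic ring of carbon only, and the maximal response stays within the scatter. No data at hand bear on why the exchange leaves this read-out unmoved.

The compounds shown leave open whether the sulfonyl sulfur needs an aromatic group at all, as a methyl or cyclohexyl group there would test. They also leave open whether a carboxylic acid or a primary amine on the aryl ring would move the maximal response beyond the scatter.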